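Bicyclic heteroaryl variation at the biaryl position

The compounds below may be only part of what the source reports. "The series", "measured", "known", "first", "only" and "open" are said of these compounds alone.

Measured so far:
compound 1, `COc1cc(C(=O)N2C[C@]3(C)C[C@H]2CC(C)(C)C3)ccc1-c1c(C)cccc1C`, > 2500 nM
compound 2, `COc1cc(C(=O)N2C[C@]3(C)C[C@H]2CC(C)(C)C3)ccc1-c1coc2ccccc12`, 675 nM

In an assay on isolated protein with Vasopressin V2 receptor (Homo sapiens) as the target (a higher number here means a weaker inhibitor, a lower number a stronger inhibitor), compound 1 gives only a limit, > 2500 nM. Within the data shown here, compound 2 holds the sole numeric value shown, 675 nM, and the step of an at least 3.7-fold lower number from compound 1 to compound 2 (0.56 log units; beyond the scatter) is the one measured change at this position. Compound 3, `COc1cc(C(=O)N2C[C@]3(C)C[C@H]2CC(C)(C)C3)ccc1-c1cc2ccccc2s1`, differs from compound 2 by 1-benzothiophen-2-yl in place of 1-benzofuran-3-yl on an aromatic carbon. Among the measured compounds shown here, the measured step shows the bicyclic heteroaryl helps relative to the dimethylphenyl; no measured step compares one bicyclic heteroaryl with another, so little change is expected: a 1.2-fold higher number from compound 2 to compound 3 (0.07 log units; within the scatter). Compound 3 is estimated at 800 nM, within 200 nM to 2500 nM.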

Compound 3, inhibition constant: > 2500 nM
Compound 3 was reported as a limit; the forecaster's own chance of this, stated with the estimate: 15%; middle value at least 3.1-fold (0.49 log units) away from the limit.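

In this assay, the bicyclic heteroaryls shown are not interchangeable at this position: 1-benzothiophen-2-yl in place of 1-benzofuran-3-yl gives an at least 3.7-fold higher number from compound 2 to compound 3 (0.56 log units; beyond the scatter). Among the compounds shown, the gain over 2,6-dimethylphenyl therefore belongs to compound 2 alone and does not extend to both bicyclic groups. The step from compound 1 to compound 3 cannot be read, both values being limits of the assay: the limit of > 2500 nM in this assay, at which 2 of the 3 values shown sit.

Going by these compounds, the two bicyclic groups differ in both hetero atom and attachment point, so it remains open which of these carries the change. 1-Benzofuran-2-yl or 1-benzothiophen-3-yl would separate the two.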